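The compounds below may be only part of what the source reports. "The series", "measured", "known", "first", "only" and "open" are said of these compounds alone.

Series on the shared core, read in a functional assay on DU-145 cells (Homo sapiens) for inhibition, read by sulforhodamine B assay, with a stated time of 48 h, tested at 10 uM; a higher number here means more inhibition at the concentration tested (going by the name of the read-out), a lower number less inhibition. Compound 1 `Brc1cn2ccnc2c(-c2ccc3ncn(C4CCCCC4)c3c2)n1` gives 6.2% in this assay, compound 2 `c1ccc(-c2cn3ccnc3c(-c3ccc4ncn(C5CCCCC5)c4c3)n2)cc1` gives 29.3%, and compound 3 `c1ccc2c(-c3cn4ccnc4c(-c4ccc5ncn(C6CCCCC6)c5c4)n3)cccc2c1` gives 5.1%. Compound 2 stands highest of the three numbers, with a number 23.1 percentage points higher from compound 1 to compound 2 (beyond the scatter) and a number 24.2 percentage points lower from compound 2 to compound 3 (beyond the scatter) both beyond the scatter, while a number 1.1 percentage points lower from compound 1 to compound 3 (within the scatter) stays within it. Compound 4 `c1csc(-c2cn3ccnc3c(-c3ccc4ncn(C5CCCCC5)c4c3)n2)c1` follows from compound 2 by thiophen-2-yl in place of phenyl on an aromatic carbon. Among the measured compounds shown here, the steps that bear on it are the two that exchange the group at the same place, a number 23.1 percentage points higher from compound 1 to compound 2 (beyond the scatter) and a number 24.2 percentage points lower from compound 2 to compound 3 (beyond the scatter), both modest and in opposite directions, so a modest downward step in this assay or none beyond the scatter is expected, namely a number 9.3 percentage points lower from compound 2 to compound 4 (within the scatter). Compound 4 is therefore estimated at 20%, between 5% and 38%.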

Compound 4, a percentage reported as inhibition, at one concentration (the size of the read-out at that concentration, not a potency): 5.07%
The estimate for compound 4 lay 14.9 percentage points above the measured number; low and high end bracket the measured number.
By their numbers in this assay, from the lowest: compounds 4, 3 and 1 (each within the scatter of the next); then compound 2.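

In this assay, the step to thiophen-2-yl, a number 24.2 percentage points lower from compound 2 to compound 4 (beyond the scatter), shows that the number reached with phenyl at this position does not carry over to a five-membered aromatic ring with sulfur. Thiophen-2-yl cannot be told apart from naphthalen-1-yl or bromo, with a number 0 percentage points lower from compound 3 to compound 4 (within the scatter) and a number 1.1 percentage points lower from compound 1 to compound 4 (within the scatter), so among the groups shown only phenyl stands apart, and compound 3 and compound 4 show that an aromatic ring here does not suffice. Nothing available explains this difference. Open, on these data alone, is whether phenyl carrying a methoxy group or an amine keeps the number of compound 2. As far as these compounds go, a pyridine ring at this position is equally open.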